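Removing a Methoxy Group from a Chromone Dithiocarbamate

A few compounds are considered here, and "the series" means these few. Any claim that something is new, unique, unknown or untested is made for them only; others in the source may bear on it.

Measured compounds:
Compound 1, `O=c1c(CSC(=S)N2CCCC2)coc2ccccc12`, gives 2300 nM in a functional assay on SW480 cells (Homo sapiens) for antiproliferative activity, read by MTT assay, with a stated time of 72 h; a higher number here means a weaker inhibitor, a lower number a stronger inhibitor.
Compound 2, `COc1ccc2occ(CSC(=S)N3CCCC3)c(=O)c2c1`, gives 4800 nM in this assay.
Compound 3, `COc1ccc2occ(CSC(=S)N3CCCCC3)c(=O)c2c1`, gives 6700 nM in this assay.

The three measured compounds share a chromone core joined through a methylene and a sulfur to a thiocarbonyl that carries a cyclic amine. Compound 3 sits at the weak end of the set: the gap to compound 2 is within the scatter, while compound 1 lies clearly further off.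

Compound 4, `O=c1c(CSC(=S)N2CCCCC2)coc2ccccc12`, has not yet been measured. It differs from compound 3 by hydrogen in place of methoxy on an aromatic carbon. The same change has already been made once, from compound 2 to compound 1, where it is described by hydrogen in place of methoxy on an aromatic carbon. That change produced a 2.1-fold lower number from compound 2 to compound 1 (0.32 log units; beyond the scatter), so a modest gain in potency. The two cores on which the change is made differ by piperidin-1-yl in place of pyrrolidin-1-yl on a thiocarbonyl carbon, and that exchange gave a 1.4-fold higher number from compound 2 to compound 3 (0.14 log units; within the scatter).

Since the place of the change is the same word for word in both pairs, and since the core difference itself made little mark on the result, a similar-sized gain is the natural expectation. The expectation for compound 4 is a 2.1-fold lower number from compound 3 to compound 4 (0.32 log units; beyond the scatter), resting on the step seen from compound 2 to compound 1. Compound 4 is therefore estimated at 3200 nM, expected to fall between 1500 nM and 7000 nM.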

Compound 4, half-maximal inhibitory concentration: 1200 nM
Compound 4: the middle estimate sits 2.7-fold (0.43 log units) above what was measured; the whole stated range lies above it.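

In this assay, going by these compounds alone, taking the methoxy group off compound 3 gives a 5.6-fold lower number from compound 3 to compound 4 (0.75 log units; beyond the scatter), so hydrogen in place of methoxy goes the same way on both cores, but not by the same amount: the same change on two cores in this assay, a 2.1-fold lower number (0.32 log units; beyond the scatter) from compound 2 to compound 1 and a 5.6-fold lower number (0.75 log units; beyond the scatter) from compound 3 to compound 4, 2.7-fold (0.43 log units) apart, beyond the scatter of two such steps The same four compounds can be read the other way, through piperidin-1-yl in place of pyrrolidin-1-yl, which gives a 1.9-fold lower number from compound 1 to compound 4 (0.28 log units; within the scatter) once the methoxy group is gone, and this exchange also fails to carry over unchanged: the same change on two cores in this assay, a 1.4-fold higher number (0.14 log units; within the scatter) from compound 2 to compound 3 and a 1.9-fold lower number (0.28 log units; within the scatter) from compound 1 to compound 4, 2.7-fold (0.43 log units) apart, beyond the scatter of two such steps The direction of the methoxy step therefore held across these two cores while its size did not, so the two changes cannot simply be added together here; yet this rests on only two pairs, and it shows neither why the size differs nor how the step would behave on any other core.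

The compounds shown leave open whether the larger step is tied to piperidin-1-yl alone or would also appear with another amine on the thiocarbonyl carbon, such as morpholin-4-yl or diethylamino. They also leave open how a different group on the same aromatic carbon, such as chlorine or hydroxy, would compare with methoxy and hydrogen on either core.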